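Moving the hydroxyl on the hydrazone aryl ring

The compounds below may be only part of what the source reports. "The series", "measured", "known", "first", "only" and "open" are said of these compounds alone.

Compound 1 `O=C(N/N=C/c1ccccc1O)c1ccc(-c2ccc(F)cc2)o1` stands highest of the two numbers recorded so far. In a functional assay on KB cells (Homo sapiens) for inhibition, read by sulforhodamine B assay, with a stated time of 48 h, tested at 10 uM (on this read-out higher numbers stand for more inhibition of growth at the one concentration tested and lower numbers for less inhibition of growth), compound 1 gives 53.9%. Within the data shown here, the only other measured compound, compound 2 `O=C(N/N=C/c1ccc(Cl)cc1)c1ccc(-c2ccccc2F)o1`, differs from it in more than one place; in this assay compound 2 gives 11.3%, a number well beyond the scatter below that of compound 1, but the two differences between them cannot be separated from these values alone.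

Compound 3 `O=C(N/N=C/c1ccc(O)cc1)c1ccc(-c2ccc(F)cc2)o1` has not yet been measured. It differs from compound 1 by one change: 4-hydroxyphenyl in place of 2-hydroxyphenyl on a carbon with a double bond to nitrogen. Among the measured compounds shown here, no measured pair in this set isolates such a shift of the hydroxyl, so the size of the step is uncertain. For the measured compounds named here, the expectation here is that the step from compound 1 to compound 3 in this assay is a decrease beyond the usual scatter, written as a number 21.9 percentage points lower from compound 1 to compound 3 (beyond the scatter), because compound 1 with its 2-hydroxyphenyl is the one compound that reaches 53.9%. Compound 3 is accordingly estimated at 32%, with a range from 8% to 58%.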

Compound 3, percent growth inhibition at one concentration: 11%
Compound 3: the middle estimate sits 21 percentage points above what was measured, and the stated range covers the measured number.
By their numbers in this assay, from the lowest: compounds 3 and 2 (each within the scatter of the next); then compound 1.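

In this assay, moving the hydroxyl gives a number 42.9 percentage points lower from compound 1 to compound 3 (beyond the scatter), with 4-hydroxyphenyl in place of 2-hydroxyphenyl on a carbon with a double bond to nitrogen. Among these compounds, this is the first pair here that differs in one place, and it shows that this position is sensitive to where the hydroxyl sits on the ring: the leaving and entering groups have the same heavy atoms and the same counts of hydrogen-bond donors and acceptors, yet the step is large and beyond the scatter. Nothing available explains why the two arrangements part so widely in this read-out.

The compounds shown leave open whether the hydroxyl itself matters to the higher number of compound 1, since they do not tell how a methoxy group or an amine in its place would read in this assay. They also leave open whether a shift of the hydroxyl would give a step of similar size on a core carrying a nitrile in place of the fluorine.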